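Pyridin-2-yl replaces methanesulfonamido on the shared core

The source may report more compounds than this note shows. Statements on the series, on what has been measured and on what is new or still open speak of the compounds shown alone.

Compound 1 `CS(=O)(=O)Nc1cccc2c1CCC2c1ncc[nH]1` gives > 10000 nM in a functional assay on CHO cells for agonist activity at Alpha-1D adrenergic receptor (Homo sapiens), read by FLIPR and calcium flux (a lower number here means that less compound is needed, a higher number that more compound is needed for the effect), which is a limit of the assay. Compound 2 `Cc1ccc2c(c1NS(C)(=O)=O)CCC2c1ncc[nH]1` gives > 10000 nM in this assay, again a limit. Compound 3 `Clc1ccc2c(c1-c1ccn[nH]1)CCC2c1ncc[nH]1` gives > 10000 nM in this assay, also a limit.

Compound 1 thus stands at the limit of > 10000 nM in this assay, at which 3 of the 3 values shown sit; no number is known for it, only that the assay reports no effect up to its limit. Among the compounds with values here, the single measured step, a step that the two limits leave unreadable from compound 1 to compound 2, is unreadable for the same reason, as both ends are limits. Compound 3, which carries a different aromatic group on the core and a chlorine, shows the same limit as compound 1, so the two values together show no activity for either.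

Compound 4 `c1ccc(-c2cccc3c2CCC3c2ncc[nH]2)nc1` differs from compound 1 by pyridin-2-yl in place of methanesulfonamido on an aromatic carbon. Within the data shown here, no measured step bears on this change in a readable way. With every shown value at the limit, no step beyond the scatter can be expected in this assay in either direction; the most likely outcome is another limit.

Compound 4 is therefore expected at 20000 nM, with a range from 4000 nM to 100000 nM. The step that the limit leaves unreadable from compound 1 to compound 4 is expected to remain unreadable against the limit.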

Compound 4, half-maximal effective concentration: > 10000 nM
Compound 4 gave a limit, no number; the forecaster's own chance of this, stated with the estimate: 80%; the middle value does not contradict the limit.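

Within the data shown here, compound 1 and compound 4 both end at a limit and not at a number, so the change from methanesulfonamido to pyridin-2-yl gives no step that can be read. The compounds shown leave open whether any group on the shared core can bring a measurable effect, since all of them sit at one value: the limit of > 10000 nM in this assay, at which 4 of the 4 values shown sit.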